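The source may hold more compounds than are shown below. What is called first, only, known or untested is meant among the compounds shown, and "the series" means these compounds.

Compound 1 `CCCCCC(C)OC(=O)NC(=O)Nc1c(C(C)C)cccc1C(C)C` gives 1060 nM in an assay on microsomes from intestine for inhibition of acyl-CoA:cholesterol acyltransferase (Oryctolagus cuniculus); on this read-out lower numbers stand for stronger inhibition and higher numbers for weaker inhibition; compound 2 `CCCCCCCC(C)OC(=O)NC(=O)Nc1c(C(C)C)cccc1C(C)C` gives 390 nM; compound 3 `CCCCCCCCCCCCCCOC(=O)NC(=O)Oc1c(C(C)C)cccc1C(C)C` gives 10 nM.

Compound 2 carries the change ethyl in place of hydrogen on a saturated chain carbon, six bonds along the chain from an oxygen next to a carbonyl group relative to compound 1, and this gave a 2.7-fold lower number from compound 1 to compound 2 (0.43 log units; beyond the scatter). Compound 4 `CCCCCCCCCCCCCCCCOC(=O)NC(=O)Oc1c(C(C)C)cccc1C(C)C`, not yet measured, carries the change ethyl in place of hydrogen on a saturated chain carbon, ten or more bonds along the chain from an oxygen next to a carbonyl group relative to compound 3. The difference between the core of compound 1 and the core of compound 3 is not broken down here. The two changes are the same kind of change rather than the same: the ethyl enters at a different place along the chain in compound 2 and in compound 4. Compound 3 already stands lowest of the three. Given the step from compound 1 to compound 2, compound 4 is expected to show a 1.7-fold lower number from compound 3 to compound 4 (0.22 log units; within the scatter), a somewhat smaller step because compound 3 starts from 10 nM. Compound 4 is estimated at 6 nM, between 2 nM and 25 nM.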

Compound 4, half-maximal inhibitory concentration: 50 nM
The estimate for compound 4 lay 8.3-fold (0.92 log units) below the measured number; measured number outside the range, above it.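

On the core of compound 3, ethyl in place of hydrogen gave a 5.0-fold higher number from compound 3 to compound 4 (0.70 log units; beyond the scatter), so the step seen on the core of compound 1 did not carry over in this assay: the same change on two cores in this assay, a 2.7-fold lower number (0.43 log units; beyond the scatter) from compound 1 to compound 2 and a 5.0-fold higher number (0.70 log units; beyond the scatter) from compound 3 to compound 4, 14-fold (1.13 log units) apart, beyond the scatter of two such steps Across these two pairs, then, the same kind of change does not keep its direction from one core to the other. This does not show whether the core or the place along the chain accounts for the gap: the ethyl enters at a different place in each pair, and each core offers a single step.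

Still open, going by these compounds, is how a chain longer than that of compound 4, or an amine in place of the ethyl, would read on either core. Also open, on these data alone, is how the chain of compound 3 would read on the core of compound 1.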